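Swapping the Aryl Substituent Once More: From Fluoro to Hydroxy

The source may hold more compounds than are shown below. What is called first, only, known or untested is meant among the compounds shown, and "the series" means these compounds.

The three measured compounds share a core and differ only in the group carried on the aromatic ring. Compound 1 `C=C(C)[C@@H]1CC=C(C)/C(=N/NC(=O)Nc2nnc(-c3ccc(Cl)cc3)o2)C1` carries chloro, compound 2 `C=C(C)[C@@H]1CC=C(C)/C(=N/NC(=O)Nc2nnc(-c3ccc([N+](=O)[O-])cc3)o2)C1` nitro, and compound 3 `C=C(C)[C@@H]1CC=C(C)/C(=N/NC(=O)Nc2nnc(-c3ccc(F)cc3)o2)C1` fluoro. In a functional assay on the whole organism (strain Swiss albino) with Mus musculus as the target, with a stated time of 0.5 h (a higher number here means that more compound is needed for the effect, a lower number that less compound is needed), compound 1 gives 100 mg/kg, compound 2 gives 100 mg/kg, and compound 3 gives 100 mg/kg. The three exchanges at this position produced no change at the digits printed from compound 1 to compound 2 (within the scatter), no change at the digits printed from compound 1 to compound 3 (within the scatter) and no change at the digits printed from compound 2 to compound 3 (within the scatter), so compound 3 stands level with compounds 1 and 2 in this assay.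

Compound 4 `C=C(C)[C@@H]1CC=C(C)/C(=N/NC(=O)Nc2nnc(-c3ccc(O)cc3)o2)C1` is the next variation at the same place: hydroxy in place of fluoro on an aromatic carbon. All three measured steps bear on it, since each also replaces one group by another on that aromatic carbon, and none of them moved the result beyond the scatter. Compound 4 is therefore expected to show no change at the digits printed from compound 3 to compound 4 (within the scatter) in this assay, that is no step beyond the scatter. For compound 4 the estimate in this assay is 100 mg/kg, with a range from 50 mg/kg to 200 mg/kg.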

Compound 4, minimum effective dose: 100 mg/kg
Beside the measured number, compound 4's estimate shows no gap at the digits printed; low and high end bracket the measured number.
By their numbers in this assay, from the lowest: compounds 1, 2, 3 and 4 (each within the scatter of the next).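

In this assay, the position on the aromatic ring now also tolerates hydroxy, a group that, unlike fluoro, counts as a hydrogen-bond donor and acceptor, and the exchange for fluoro shows (no change at the digits printed from compound 3 to compound 4 (within the scatter)). The same holds when hydroxy is set against the other two groups, with the nitro exchange showing (no change at the digits printed from compound 2 to compound 4 (within the scatter)) and the chloro exchange showing (no change at the digits printed from compound 1 to compound 4 (within the scatter)). All four groups at this place thus read alike, so gaining a hydrogen-bond donor here leaves the minimum effective dose within the scatter, and no available evidence accounts for this flat result.

As far as these compounds go, whether an amine, a carboxylic acid or a longer chain such as butoxy at this place would separate from these four remains open. The compounds shown also leave open whether any change to the shared core would move the dose.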